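Chain Length on Two Cores and Adrenergic Agonism

The source may hold more compounds than are shown below. What is called first, only, known or untested is meant among the compounds shown, and "the series" means these compounds.

Compound 1, with the structure `CCCn1ncnc1-c1ccccc1NCC1=NCCN1`, was tested in an in vitro functional assay on cells (Fibroblast) for agonist activity at Alpha-1D adrenergic receptor (Homo sapiens); on this read-out lower numbers stand for an effect already at smaller amounts and higher numbers for an effect only at larger amounts of compound; in it compound 1 gives 251 nM. Compound 2, `CCCCn1ncnc1-c1ccccc1NCC1=NCCN1`, carries one more carbon on the chain attached to the ring nitrogen. In this assay compound 2 gives 398 nM. The difference between the two is methyl in place of hydrogen on a saturated chain carbon, three bonds along the chain from an aromatic nitrogen, and the step is a 1.6-fold higher number from compound 1 to compound 2 (0.20 log units; within the scatter).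

Compound 3, `CCn1nccc1-c1ccccc1NCC1=NCCN1`, is built on a different core; how the cores of compound 1 and compound 3 differ is not broken down here. In this assay compound 3 gives only a limit, < 100000 nM, and no number. This is the limit of < 100000 nM in this assay, at which 1 of the 3 values shown sits.

Compound 4, `CCCn1nccc1-c1ccccc1NCC1=NCCN1`, has not yet been measured in this assay. It differs from compound 3 by methyl in place of hydrogen on a saturated chain carbon, two bonds along the chain from an aromatic nitrogen. This is the same kind of change as that from compound 1 to compound 2, but not the same: here the methyl enters two bonds along the chain from an aromatic nitrogen, whereas from compound 1 to compound 2 it entered three bonds along the chain from an aromatic nitrogen. Because the measured step of a 1.6-fold higher number from compound 1 to compound 2 (0.20 log units; within the scatter) lies within the scatter, the expected step is a step that the limit leaves unreadable from compound 3 to compound 4. Since compound 3 is known only as a limit, the starting point for this expectation is itself uncertain. Compound 4 is expected to give about 3000 nM in this assay, within a range from 150 nM to 60000 nM.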

Compound 4, half-maximal effective concentration: < 100000 nM
Compound 4 ended at the assay's limit; the forecaster's own chance of this, stated with the estimate: 35%; the middle value lies beyond the limit too.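

The step from compound 3 to compound 4 cannot be read in this assay, as each of the two compounds gives only a limit and no number: the limit of < 100000 nM in this assay, at which 2 of the 4 values shown sit.

The compounds shown leave open whether lengthening the chain on the core of compound 3 changes the read-out at all, and how far that core differs from the core of compound 1 when both carry the same chain.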